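Aryl swap on the ring nitrogen of the shared core

This account rests on a few compounds, and the source may have more. Where it says the series, first, only, none or still open, it means among the compounds named here.

Compound 1 `COc1cc(/C=C/C(C)=O)ccc1OCc1cn(-c2ccccc2CO)nn1` carries 2-(hydroxymethyl)phenyl on the ring nitrogen of the shared core. In a functional assay on MCF7 cells (Homo sapiens) for antiproliferative activity, read by MTT assay, with a stated time of 48 h (on this read-out lower numbers stand for stronger inhibition and higher numbers for weaker inhibition), compound 1 gives 65800 nM, the highest of the three numbers measured. Compound 3 `COc1cc(/C=C/C(C)=O)ccc1OCc1cn(-c2ccc(-c3ccccc3)cc2)nn1` gives 65400 nM in this assay, within the scatter of compound 1. Compound 2 `COc1cc(/C=C/C(C)=O)ccc1OCc1cn(-c2ccccc2Cl)nn1` gives 2190 nM, and the step of a 30-fold lower number from compound 1 to compound 2 (1.48 log units; beyond the scatter) is the only one that reaches beyond the scatter.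

Compound 4 `COc1cc(/C=C/C(C)=O)ccc1OCc1cn(-c2ccc(C=O)cc2)nn1` is the next point on this route. Relative to compound 1 the change is 4-formylphenyl in place of 2-(hydroxymethyl)phenyl on an aromatic nitrogen. Among the measured compounds shown here, only the step from compound 1 to compound 2 touches the same group, and it removed the hydroxymethyl donor with a large drop in the number. Compound 3 shows that another 4-substituted phenyl at this place leaves the number where compound 1 stands. For compound 4 the expectation is a moderate lowering, a 3.3-fold lower number from compound 1 to compound 4 (0.52 log units; beyond the scatter), not as large as the step to compound 2. The estimate for compound 4 is 20000 nM, with a range from 4000 nM to 70000 nM.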

Compound 4, half-maximal inhibitory concentration: 86400 nM
Compound 4: the middle estimate sits 4.3-fold (0.64 log units) below what was measured, outside the stated range (above it).
By their numbers in this assay, from the lowest: compound 2; then compounds 3, 1 and 4 (each within the scatter of the next).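

In this assay, the exchange of 2-(hydroxymethyl)phenyl for 4-formylphenyl gives a 1.3-fold higher number from compound 1 to compound 4 (0.12 log units; within the scatter), so removing hydroxymethyl does not by itself bring the number towards that of compound 2. Formyl in place of phenyl on the aromatic carbon gives a 1.3-fold higher number from compound 3 to compound 4 (0.12 log units; within the scatter), so these two 4-substituted phenyl groups cannot be told apart here. Among the compounds shown here, the remaining step, a 39-fold higher number from compound 2 to compound 4 (1.60 log units; beyond the scatter), leaves 2-chlorophenyl as the only aryl group of the four that stands apart, with compounds 1, 3 and 4 together at the high end.

No measurement at hand accounts for the separate standing of 2-chlorophenyl. From the compounds shown here alone, whether this depends on chloro itself or on where it sits stays open, and 4-chlorophenyl, 2-formylphenyl or 2-aminophenyl on the ring nitrogen of the shared core would help to separate the two.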